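This account rests on a few compounds, and the source may have more. Where it says the series, first, only, none or still open, it means among the compounds named here.

Among the compounds with values here, compound 3 `Oc1ccc(-c2cc(-c3ccc(C(F)(F)F)cc3)cc(-c3cccc(O)c3)n2)cc1` gives 2870 nM in a functional assay on T47D cells (Homo sapiens) for inhibition (a higher number here means a weaker inhibitor, a lower number a stronger inhibitor), the lowest of the two numbers measured so far. Compound 2 `Oc1ccc(-c2cc(-c3ccccc3C(F)(F)F)cc(-c3cccc(O)c3)n2)cc1` gives 3210 nM in this assay, and the step of a 1.1-fold lower number from compound 2 to compound 3 (0.05 log units; within the scatter) lies within the scatter. Compound 1 `Oc1ccc(-c2cc(-c3ccc(C(F)(F)F)cc3)cc(-c3ccccc3O)n2)cc1` reaches only the limit > 50000 nM in this assay (the limit of > 50000 nM in this assay, at which 1 of the 3 values shown sits). The step of an at least 17-fold lower number from compound 1 to compound 3 (1.24 log units; beyond the scatter) shows that where the hydroxyl sits on one outer ring matters greatly. Compound 4 `Oc1ccc(-c2cc(-c3ccc(C(F)(F)F)cc3)cc(-c3ccc(O)cc3)n2)cc1` is the next variation: 4-hydroxyphenyl in place of 3-hydroxyphenyl on an aromatic carbon. Within the data shown here, only the step from compound 1 to compound 3 bears on a move of this hydroxyl, and its direction for this new position cannot be read from it, so the expected step of a 1.1-fold lower number from compound 3 to compound 4 (0.06 log units; within the scatter) is set near no change beyond the scatter. Compound 4 is therefore estimated at 2500 nM, between 600 nM and 10000 nM.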

Compound 4, half-maximal inhibitory concentration: > 50000 nM
Compound 4 was reported as a limit (the forecaster's own chance of this, stated with the estimate: 5%); at least 20-fold (1.30 log units) between middle value and limit.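

Moving the hydroxyl the other way on this outer ring, next to the ring nitrogen, is also costly, with the 4-hydroxyphenyl group giving an at least 17-fold higher number from compound 3 to compound 4 (1.24 log units; beyond the scatter). Among the three hydroxyphenyl groups shown at this place, with the 4-(trifluoromethyl)phenyl group kept, only the 3-hydroxyphenyl group of compound 3 gives a measurable number. Compound 1 and compound 4 each stand at a limit, so the step between them cannot be read: the limit of > 50000 nM in this assay, at which 2 of the 4 values shown sit.

As far as these compounds go, whether an amine or a carboxylic acid at this ring position would keep the number of compound 3 remains open.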